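A few compounds are considered here, and "the series" means these few. Any claim that something is new, unique, unknown or untested is made for them only; others in the source may bear on it.

Measured so far:
Compound 1, `Cc1cc(C)c(NC(=O)N(Cc2ccc(-c3nnc(C)o3)cc2)C2CCCCCC2)c(C)c1`: > 0.32 mg/kg
Compound 2, `O=C(Nc1c(F)cc(F)cc1F)N(Cc1cccc(-c2cc[nH]n2)c1)C1CCCCCC1`: 0.062 mg/kg

Compound 1 gives in a functional assay on a cell-free system (plasma) with sterol O-acyltransferase, Soat (Rattus norvegicus) as the target (on this read-out lower numbers stand for an effect already at smaller amounts and higher numbers for an effect only at larger amounts of compound), only a limit, > 0.32 mg/kg, and not a number. Compound 2 gives in this assay a value of 0.062 mg/kg. Among the compounds with values here, this is the only number in the set; the one other entry is the limit of > 0.32 mg/kg in this assay, at which 1 of the 2 values shown sits, so compound 2 cannot be ranked against anything, and no pair of measured compounds differs in a single place, so no measured step exists.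

Compound 3, `O=C(Nc1c(F)cc(F)cc1F)N(Cc1ccccc1)Cc1cccc(-c2cc[nH]n2)c1`, is still to be tested in this assay. It differs from compound 2 by benzyl in place of cycloheptyl on an amide-type nitrogen. Within the data shown here, compound 3 also keeps the pyrazolyl-bearing benzyl and the trifluorophenyl urea of compound 2, so only this one exchange is in play.

Among the measured compounds shown here, no measured step covers such an exchange. The step from compound 2 to compound 3 is expected to be a loss beyond the usual scatter, a 3.2-fold higher number from compound 2 to compound 3 (0.51 log units; beyond the scatter), with real uncertainty about its size. Compound 3 is therefore estimated at 0.2 mg/kg, with a range from 0.06 mg/kg to 0.6 mg/kg.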

Compound 3, dose for half-maximal effect: 0.096 mg/kg
Estimate against measurement, compound 3: 2.1-fold (0.32 log units) above; low and high end bracket the measured number.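

In this assay, the amide-type nitrogen of this series carries benzyl as well as cycloheptyl without a change that can be told from the usual spread of repeat measurements: a 1.5-fold higher number from compound 2 to compound 3 (0.19 log units; within the scatter). Within the data shown here, this is the first measured step, and compound 2 alone could not show that the seven-membered non-aromatic ring can give way at this place to a six-membered aromatic ring, with compound 3 at 0.096 mg/kg in this assay. Nothing on hand bears on why the two groups read alike here.

Among these compounds, the exchange rests on a single pair, with the pyrazolyl-bearing benzyl and the trifluorophenyl urea held fixed, so it stays open whether benzyl and cycloheptyl would also read alike on another part of the core, such as the one in compound 1. Also open, as far as these compounds go, is how this same nitrogen responds to methyl, to a longer chain such as n-hexyl, to a piperidine amine, or to a carboxylic acid carried on the benzyl of compound 3.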